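The compounds below may be only part of what the source reports. "The series", "measured", "known", "first", "only" and "open" are said of these compounds alone.

Compound 1: `CCn1cnc(C(C[C@H]2CC[C@H](N)C2)C(=O)O)c1`, 150 nM
Compound 2: `CC(C)CCn1cnc(C(CCCCN)C(=O)O)c1`, 160 nM

In an assay on isolated protein for inhibition of carboxypeptidase B (Homo sapiens) (a lower number here means a stronger inhibitor, a higher number a weaker inhibitor), compound 1 gives 150 nM, the lower of the two numbers measured, while compound 2 gives 160 nM; the two values lie within the scatter of each other, so neither can be called the stronger inhibitor. Compound 3 `CC(C)(C)CCn1cnc(C(C[C@H]2CC[C@H](N)C2)C(=O)O)c1` is not yet measured; it differs from compound 1 by tert-butyl in place of hydrogen on a saturated chain carbon, two bonds along the chain from an aromatic nitrogen. Going by the values given here, no direct step of this kind is available among the measured compounds. He expects the step from compound 1 to compound 3 to be a 1.4-fold lower number from compound 1 to compound 3 (0.13 log units; within the scatter), within or near the scatter. Compound 3 is therefore estimated at 110 nM, with a range from 35 nM to 350 nM.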

Compound 3, half-maximal inhibitory concentration: 1 nM
Compound 3: the middle estimate sits 110-fold (2.04 log units) above what was measured; measured number below the stated range.
By their numbers in this assay, from the lowest: compound 3; then compounds 1 and 2 (each within the scatter of the next).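

In this assay, replacing hydrogen with tert-butyl on a saturated chain carbon, two bonds along the chain from an aromatic nitrogen, gives a 150-fold lower number from compound 1 to compound 3 (2.18 log units; beyond the scatter) and is a large step. Going by these compounds alone, this shows that the potency of the shared core depends strongly on what this position carries, which the earlier compounds, differing in more than one place, could not show. No available evidence accounts for the size of this step. From the compounds shown here alone, it remains open whether a smaller isopropyl group or a cyclohexyl ring at this carbon would give a similar step. Going by these compounds, whether tert-butyl has the same effect on other side chains also remains open.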